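Compound 4 and a flat cytotoxicity read-out

The source may hold more compounds than are shown below. What is called first, only, known or untested is meant among the compounds shown, and "the series" means these compounds.

In a functional assay on Huh-5-2 cells (Homo sapiens), read by MTT assay (a higher number here means that more compound is tolerated, a lower number that less compound is tolerated), compound 1 (`CC(=O)c1ccc(-c2ccc(Cl)cc2)c(COc2ccc(-c3nc4cc(C(=O)O)ccc4n3C3CCCCC3)cc2)c1`) gives 24000 nM and compound 2 (`CN(C)c1ccc(-c2ccc(Cl)cc2)c(COc2ccc(-c3nc4cc(C(=O)O)ccc4n3C3CCCCC3)cc2)c1`) gives 30000 nM as its half-maximal cytotoxic concentration. Compound 3 (`O=C(O)c1ccc2c(c1)nc(-c1ccc(OCc3cc(C(=O)NCCO)ccc3-c3ccc(Cl)cc3)cc1F)n2C1CCCCC1`) stands at 26000 nM on the same scale, within the scatter of both others, so it holds no distinct rank among the three.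

The move to compound 4 (`CN(C)C(=O)Nc1ccc(-c2ccc(Cl)cc2)c(COc2ccc(-c3nc4cc(C(=O)O)ccc4n3C3CCCCC3)c(F)c2)c1`), not yet measured, puts (dimethylcarbamoyl)amino in place of (2-hydroxyethyl)carbamoyl on an aromatic carbon, para to a 4-chlorophenyl group ((dimethylcarbamoyl)amino in place of (2-hydroxyethyl)carbamoyl on an aromatic carbon). Going by the values given here, the one measured step that bears on this is also an exchange on an aromatic carbon, dimethylamino in place of acetyl in going to compound 2 (a 1.3-fold higher number from compound 1 to compound 2 (0.10 log units; within the scatter)), and it stays within the scatter. From that single step, which involves different groups and is thin support, no change beyond the scatter is expected in this assay here. The expected step (a 1.0-fold higher number from compound 3 to compound 4 (0.02 log units; within the scatter)) is accordingly small. Compound 4 is estimated at 27000 nM with an expected range from 14000 nM to 48000 nM in this read-out.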

Compound 4, half-maximal cytotoxic concentration: 25000 nM
Compound 4: the middle estimate sits 1.1-fold (0.03 log units) above what was measured; measured number inside the range.
By their numbers in this assay, from the lowest: compounds 1, 4, 3 and 2 (each within the scatter of the next).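

At the aromatic carbon para to a 4-chlorophenyl group, (dimethylcarbamoyl)amino in place of (2-hydroxyethyl)carbamoyl leaves the read-out in this assay essentially flat, with a 1.0-fold lower number from compound 3 to compound 4 (0.02 log units; within the scatter) staying within the scatter. The exchange keeps 6 heavy atoms but goes from 2 hydrogen-bond donors and 2 acceptors to 1 of each, so this position now shows a within-scatter step for a change in those counts, alongside a 1.3-fold higher number from compound 1 to compound 2 (0.10 log units; within the scatter) on the related compounds. Nothing shown here explains why the number holds steady.

Going by these compounds, whether a primary amine, a carboxylic acid or a longer chain at this carbon would move the number beyond the scatter remains open. So does whether a sulfonamide there would stay equally flat, since every value shown lies in one narrow band.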